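Swapping the pyridine in a naphthalene sulfonamide series

The compounds below may be only part of what the source reports. "The series", "measured", "known", "first", "only" and "open" are said of these compounds alone.

Three compounds share a common core and differ only in the aromatic group attached to the carbonyl carbon of the amide. Compound 1 `CCCC(=O)N1CCC(NS(=O)(=O)c2ccc(NC(=O)c3ccc(C)cc3)c3ccccc23)CC1` carries a methylphenyl group and in an in vitro functional assay on CHO/Galpha16 cells for antagonist activity at C-C chemokine receptor type 8 (Homo sapiens), read by FLIPR (on this read-out higher numbers stand for weaker inhibition and lower numbers for stronger inhibition), compound 1 gives 9.5 nM. Compound 2 `CCCC(=O)N1CCC(NS(=O)(=O)c2ccc(NC(=O)c3ccc(C(C)(C)C)cc3)c3ccccc23)CC1` carries a tert-butylphenyl group and gives 6.9 nM; the change is a 1.4-fold lower number from compound 1 to compound 2 (0.14 log units; within the scatter). Compound 3 `CCCC(=O)N1CCC(NS(=O)(=O)c2ccc(NC(=O)c3cc(C)nc(Cl)c3)c3ccccc23)CC1` carries a chloromethylpyridinyl group and gives 43.9 nM, the highest of the three numbers, with a 4.6-fold higher number from compound 1 to compound 3 (0.66 log units; beyond the scatter) and a 6.4-fold higher number from compound 2 to compound 3 (0.80 log units; beyond the scatter).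

Compound 4 `CCCC(=O)N1CCC(NS(=O)(=O)c2ccc(NC(=O)c3ccccn3)c3ccccc23)CC1` is the next step: pyridin-2-yl in place of 2-chloro-6-methylpyridin-4-yl on a carbonyl carbon. The two measured steps that change the aromatic group both moved the number upward by a modest amount, but neither compares two pyridine rings with each other, so they give only an indirect guide. Keeping a pyridine while removing the chloro and methyl groups is expected to leave the number near that of compound 3, with a 1.1-fold higher number from compound 3 to compound 4 (0.06 log units; within the scatter) as the estimated step. Compound 4 is therefore expected to give about 50 nM, most likely between 15 nM and 200 nM.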

Compound 4, half-maximal inhibitory concentration: 41.7 nM
The estimate for compound 4 lay 1.2-fold (0.08 log units) above the measured number; low and high end bracket the measured number.
By their numbers in this assay, from the lowest: compounds 2 and 1 (each within the scatter of the next); then compounds 4 and 3 (each within the scatter of the next).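

The two pyridine compounds give matching results in this assay, with a 1.1-fold lower number from compound 3 to compound 4 (0.02 log units; within the scatter), even though pyridin-2-yl lacks the chloro and methyl groups of 2-chloro-6-methylpyridin-4-yl and joins the carbonyl carbon through a different ring position. The gap to the phenyl compounds also remains without those two groups: there is a 4.4-fold higher number from compound 1 to compound 4 (0.64 log units; beyond the scatter) and a 6.0-fold higher number from compound 2 to compound 4 (0.78 log units; beyond the scatter), so among these four compounds, both pyridines give higher numbers than both substituted phenyl rings. No measurement shown explains this gap.

As far as these compounds go, because the chloro group, the methyl group and the ring position all change together between these two pyridines, their separate contributions remain unknown. An unsubstituted phenyl, a pyridin-3-yl or a 6-methylpyridin-2-yl group at this position would help show how much depends on the ring nitrogen and how much on the substituents.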